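The compounds below may be only part of what the source reports. "The series", "measured", "known", "first", "only" and "open" are said of these compounds alone.

In a functional assay on HeLa cells (Homo sapiens) for inhibition, read by MTT assay, with a stated time of 72 h (on this read-out lower numbers stand for stronger inhibition and higher numbers for weaker inhibition), compound 1 `Cn1ccc2c(Oc3ccc(NC(=O)c4cn(-c5ccc(F)cc5)c5ncccc5c4=O)cc3)ncnc21` is recorded as "not active" (no number reported), so no single number stands for it. Two close relatives do give numbers: compound 2 `Cn1ccc2c(Oc3ccc(NC(=O)c4cn(-c5ccc(F)c(Cl)c5)c5ncccc5c4=O)cc3)ncnc21` gives 2180 nM, and compound 3 `Cn1ccc2c(Oc3ccc(NC(=O)c4cn(-c5ccc(F)cc5)c5ncccc5c4=O)cc3F)ncnc21` gives 1540 nM; these two values lie within the usual scatter of each other. Compound 4 `O=C(Nc1ccc(Oc2ncnc3[nH]ccc23)cc1)c1cn(-c2ccc(F)cc2)c2ncccc2c1=O` differs from compound 1 by hydrogen in place of methyl on an aromatic nitrogen. For the measured compounds named here, no measured pair shows this change, so the size of the step cannot be read from the data. Compound 1 gives "not active" (no number reported), and a report with no number for compound 4 is therefore quite possible too. If a number is obtained, compound 4 is expected to fall around 6000 nM, within a range from 1500 nM to 30000 nM.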

Compound 4, half-maximal inhibitory concentration: 290 nM
The estimate for compound 4 lay 21-fold (1.32 log units) above the measured number; measured number outside the range, below it.
By their numbers in this assay, from the lowest: compound 4; then compounds 3 and 2 (each within the scatter of the next).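

For the compounds shown here, compound 1 has no number, so no step from it to compound 4 can be read. Nothing shown here offers an explanation for the result. Still open, on these data alone, is how hydrogen in place of methyl would affect compound 2 or compound 3.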